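The compounds below may be only part of what the source reports. "The series", "measured", "known", "first", "only" and "open" are said of these compounds alone.

Compound 1 `CN(C)C(=O)c1cc2cnc(Nc3ccc(NC(=O)C4(C(=O)Nc5ccccc5F)CC4)cc3)nc2n1C1CCCC1` is the reference point of this small series. In a functional assay on A549 cells (Homo sapiens) for inhibition, read by CCK-8 assay, with a stated time of 72 h, tested at 1 uM (a higher number here means more inhibition of growth at the concentration tested, a lower number less inhibition of growth), compound 1 gives 79.1%, which is the highest of the three numbers available; compound 2 `COC(=O)c1ccc(NC(=O)C2(C(=O)Nc3ccc(Nc4ncc5cc(C(=O)N(C)C)n(C6CCCC6)c5n4)cc3)CC2)cc1` gives 77.1%, and compound 3 `COC(=O)c1cccc(NC(=O)C2(C(=O)Nc3ccc(Nc4ncc5cc(C(=O)N(C)C)n(C6CCCC6)c5n4)cc3)CC2)c1` gives 10.5%. The two neighbours of compound 1 thus lie at very different distances: the change to compound 2 came to a number 2 percentage points lower from compound 1 to compound 2 (within the scatter), whereas the change to compound 3 came to a number 68.6 percentage points lower from compound 1 to compound 3 (beyond the scatter), and the direct comparison between the two methoxycarbonyl isomers came to a number 66.6 percentage points lower from compound 2 to compound 3 (beyond the scatter).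

Compound 4 `COc1cccc(NC(=O)C2(C(=O)Nc3ccc(Nc4ncc5cc(C(=O)N(C)C)n(C6CCCC6)c5n4)cc3)CC2)c1` has not yet been measured. Its difference from compound 1 is 3-methoxyphenyl in place of 2-fluorophenyl on an amide-type nitrogen. Among the measured compounds shown here, none of the measured steps shows exactly this group, so the closest guides are the two amide aryl replacements already seen. Compound 2 shows that a 4-substituted phenyl can be carried without loss, while compound 3 shows that a 3-(methoxycarbonyl)phenyl collapses the number. The 3-methoxyphenyl of compound 4 shares the substitution pattern of compound 3 but not its group, so the outcome is genuinely uncertain. On balance a sizeable drop is expected for compound 4, namely a number 39.1 percentage points lower from compound 1 to compound 4 (beyond the scatter), with wide bounds. The estimate for compound 4 is 40%, between 8% and 75%.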

Compound 4, percent growth inhibition at one concentration: 77.2%
Estimate against measurement, compound 4: 37.2 percentage points below; measured number outside the range, above it.
By their numbers in this assay, from the lowest: compound 3; then compounds 2, 4 and 1 (each within the scatter of the next).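

In this assay, the 3-methoxyphenyl group on the amide-type nitrogen came to a number 1.9 percentage points lower from compound 1 to compound 4 (within the scatter) and to a number 0.1 percentage points higher from compound 2 to compound 4 (within the scatter), so this position carries it with no difference readable from 2-fluorophenyl or 4-(methoxycarbonyl)phenyl. The low number of compound 3 therefore does not follow from the placing of the substituent alone: 3-methoxyphenyl and 3-(methoxycarbonyl)phenyl carry theirs at the same numbered place, yet methoxy in place of methoxycarbonyl on an aromatic carbon gave a number 66.7 percentage points higher from compound 3 to compound 4 (beyond the scatter). Among the compounds shown, compound 3 is thus the only one that goes against an otherwise flat picture at this nitrogen, and it is separated from compound 4 by the group, not by its place.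

Nothing available bears on why these two groups give such different numbers. From the compounds shown here alone, it remains open whether a carboxylic acid, an amine or a longer alkoxy chain at that same place would follow methoxy or methoxycarbonyl, and whether compound 1, compound 2 and compound 4 would stay together at concentrations other than the single one tested.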